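One Methoxy Fewer: Expected Effect on Cell Tolerance

A few compounds are considered here, and "the series" means these few. Any claim that something is new, unique, unknown or untested is made for them only; others in the source may bear on it.

Compound 1 `COc1ccc(CNc2nc3cc(N)cc(N)c3nc2-c2ccccc2)cc1OC` gives 79400 nM in a functional assay on MDA-MB-231 cells (Homo sapiens) for inhibition, read by sulforhodamine B assay, with a stated time of 48 h (a lower number here means that less compound is tolerated, a higher number that more compound is tolerated), the highest of the two numbers measured; compound 2 `COc1cc(CNc2nc3cc(N)cc(N)c3nc2-c2ccccc2)cc(OC)c1OC` gives 31600 nM. Within the data shown here, the single measured step, a 2.5-fold lower number from compound 1 to compound 2 (0.40 log units; beyond the scatter), added a methoxy group. Compound 3 `COc1ccc(CNc2nc3cc(N)cc(N)c3nc2-c2ccccc2)cc1` goes the other way from compound 1: hydrogen in place of methoxy on an aromatic carbon, so that 3,4-dimethoxyphenyl becomes 4-methoxyphenyl. Since adding a methoxy produced a 2.5-fold lower number from compound 1 to compound 2 (0.40 log units; beyond the scatter), removing one is expected to push the number upward, though perhaps not beyond the scatter. Compound 3 is therefore estimated at 110000 nM, within 45000 nM to 270000 nM, a step of a 1.4-fold higher number from compound 1 to compound 3 (0.14 log units; within the scatter).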

Compound 3, concentration lethal to 50% of the cells: 64600 nM
Estimate against measurement, compound 3: 1.7-fold (0.23 log units) above, and the stated range covers the measured number.
By their numbers in this assay, from the lowest: compound 2; then compounds 3 and 1 (each within the scatter of the next).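

In this assay, hydrogen in place of methoxy on this aromatic carbon, ortho to a methoxy group, gives a 1.2-fold lower number from compound 1 to compound 3 (0.09 log units; within the scatter), so the read-out does not separate 3,4-dimethoxyphenyl from 4-methoxyphenyl. Methoxy at this carbon is therefore not shown to matter here, even though the other listed change gave a 2.5-fold lower number from compound 1 to compound 2 (0.40 log units; beyond the scatter) and lay beyond the scatter. Nothing available explains this outcome.

Still open, from the compounds shown here alone, is whether an amine, a fluorine atom or an ethoxy group on this carbon would separate from compound 1. Also open, going by these compounds, is how a phenyl group with no methoxy at all would compare with compound 3.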